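A few compounds are considered here, and "the series" means these few. Any claim that something is new, unique, unknown or untested is made for them only; others in the source may bear on it.

Three compounds have so far been measured in a functional assay on the whole organism (strain Wistar) for inhibition, with Rattus norvegicus as the target, read by paw edema, with stated times of 1 h and 3 h, at a dose of 200 mg/kg by the oral route; a higher number here means more inhibition at the dose given (going by the name of the read-out), a lower number less inhibition:

Compound 1, `Cc1ccc(/C=C2\CCCC(CN(C)c3ccc(C)cc3)C2=O)cc1`, gives 38.3%.
Compound 2, `Cc1ccc(/C=C2\CCCC(CN(C)c3cccc(C)c3)C2=O)cc1`, gives 36.2%.
Compound 3, `COc1ccc(C2(O)/C(=C/c3ccc(C)cc3)CCCC2CN(C)c2ccc(C)cc2)cc1`, gives 29.8%.

Compound 1 and compound 2 share one core and differ in a single place: 3-methylphenyl in place of 4-methylphenyl on an amine nitrogen. In this assay that change gave a step of a number 2.1 percentage points lower from compound 1 to compound 2 (within the scatter), so the two numbers cannot be told apart. Compound 3 is built on a different core; the difference between the two cores is not broken down here. Compound 3 has the lowest of the three numbers, but its gaps to compound 2 and to compound 1 both lie within the scatter, so no order among the three can be read from these values.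

For the measured compounds named here, the unmeasured compound 4, `COc1ccc(C2(O)/C(=C/c3ccc(C)cc3)CCCC2CN(C)c2cccc(C)c2)cc1`, arises from compound 3 by the same kind of change as the one between compound 1 and compound 2: 3-methylphenyl in place of 4-methylphenyl on an amine nitrogen. The place is described identically in both pairs, an amine nitrogen with two saturated chain carbons as its other neighbours. This change occurs only twice among the compounds shown, and the one measured instance sits on a different core, so the expectation rests on a single observation. In this assay the step is expected to be a number 2.1 percentage points lower from compound 3 to compound 4 (within the scatter), resting on a number 2.1 percentage points lower from compound 1 to compound 2 (within the scatter). Compound 4 is therefore expected to give 27.7% in this assay. The range expected for compound 4 runs from 17% to 38%.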

Compound 4, a percentage reported as inhibition, in the whole organism at one dose (the size of the read-out at that dose, not a potency): 29.8%
Compound 4: middle estimate off by 2.1 percentage points, on the low side, within the range that was stated.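

In this assay, putting 3-methylphenyl in place of 4-methylphenyl on the amine nitrogen gave no change at the digits printed from compound 3 to compound 4 (within the scatter) and so left two numbers that cannot be told apart, just as on the core of compound 1. This shows that in this series the change gave no readable step on either of the two cores, and that nothing here points to the core altering its effect. It does not show that the change is without effect in general or that a real effect would carry over, since two steps that both lie inside the scatter are a weak test and rest on only two pairs of compounds, read at a single dose: the same change on two cores in this assay, a number 2.1 percentage points lower (within the scatter) from compound 1 to compound 2 and no change at the digits printed (within the scatter) from compound 3 to compound 4, 2.1 percentage points apart, within the scatter of two such steps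

The compounds shown vary this part of the molecule only by moving one methyl group on the phenyl ring, so they leave open whether a more different group on that amine nitrogen, such as a 4-chlorophenyl or a benzyl group, would give a step beyond the scatter. If such a step appeared, it would remain to be seen whether it came out the same on both cores.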